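Heptyl to hexyl on the core of compound 3

The source may report more compounds than this note shows. Statements on the series, on what has been measured and on what is new or still open speak of the compounds shown alone.

Among the compounds with values here, compound 3 `CCCCCCCn1c(N2CCN(C)CC2)nc2ccccc21` gives 150 nM in a functional assay on ileum for inhibition of histamine H1 receptor (Cavia porcellus) (on this read-out higher numbers stand for weaker inhibition and lower numbers for stronger inhibition), the highest of the three numbers so far; compound 2 `CCOCCn1c(N2CCN(C)CC2)nc2ccccc21` gives 10 nM and compound 1 `CN1CCN(c2nc3ccccc3n2CCOc2ccccc2)CC1` gives 6.9 nM. The steps into compound 3 are large: a 22-fold higher number from compound 1 to compound 3 (1.34 log units; beyond the scatter) and a 15-fold higher number from compound 2 to compound 3 (1.18 log units; beyond the scatter), while a 1.4-fold higher number from compound 1 to compound 2 (0.16 log units; within the scatter). Compound 4 `CCCCCCn1c(N2CCN(C)CC2)nc2ccccc21` differs from compound 3 by hydrogen in place of methyl on a saturated chain carbon, six bonds along the chain from an aromatic nitrogen, a shortening of the chain with no oxygen involved. Within the data shown here, no measured step changes a chain by a single methyl alone; both large steps swap an oxygen-bearing group for pentyl, so they bear only indirectly on this change. A step within the scatter is therefore expected, a 1.3-fold lower number from compound 3 to compound 4 (0.10 log units; within the scatter). Compound 4 is estimated at 120 nM, with a range from 40 nM to 400 nM.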

Compound 4, half-maximal inhibitory concentration: 26 nM
Compound 4: the middle estimate sits 4.6-fold (0.66 log units) above what was measured, outside the stated range (below it).
By their numbers in this assay, from the lowest: compounds 1 and 2 (each within the scatter of the next); then compound 4; then compound 3.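

In this assay the loss of one methyl, six bonds along the chain from an aromatic nitrogen, is not neutral: a 5.8-fold lower number from compound 3 to compound 4 (0.76 log units; beyond the scatter) comes with the change from heptyl to hexyl. The all-carbon hexyl chain still gives higher numbers than the oxygen-bearing chains, with a 2.6-fold higher number from compound 2 to compound 4 (0.41 log units; beyond the scatter) and a 3.8-fold higher number from compound 1 to compound 4 (0.58 log units; beyond the scatter), yet these steps are modest where those into compound 3 are large, so an all-carbon chain alone does not carry the large loss. Nothing available explains this result. As far as these compounds go, whether a pentyl or an octyl chain on the same core extends this trend stays open, as does the effect of an amine on the hexyl chain.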